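Morpholine amide in place of methoxy on the shared core

The compounds below may be only part of what the source reports. "The series", "measured", "known", "first", "only" and "open" are said of these compounds alone.

Going by the values given here, compound 2 `CC#C[C@@H](CC(=O)O)c1ccc(OC[C@H]2COc3ccc(OC)cc3O2)cc1` gives the lowest of the two numbers measured so far in a functional assay on HEK293 cells for agonist activity at Free fatty acid receptor 1 (Homo sapiens), read by fluorescence and calcium flux, with a stated time of 10 min (on this read-out lower numbers stand for an effect already at smaller amounts and higher numbers for an effect only at larger amounts of compound), with 130 nM; compound 1 `Cn1ccnc1C(CC(=O)O)c1ccc(OCC2COc3ccc(Cl)cc3O2)cc1` gives 5880 nM in this assay, a gap described as beyond the usual scatter. Compound 3 `CC#C[C@@H](CC(=O)O)c1ccc(OC[C@H]2COc3ccc(C(=O)N4CCOCC4)cc3O2)cc1` differs from compound 2 by (morpholin-4-yl)carbonyl in place of methoxy on an aromatic carbon. Among the compounds with values here, no measured pair shows this particular change, so compound 3 is expected to stay close to compound 2, with at most a modest step toward higher numbers, a 1.9-fold higher number from compound 2 to compound 3 (0.28 log units; within the scatter). The value of compound 3 in this assay is estimated at 250 nM, within 60 nM to 1000 nM.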

Compound 3, half-maximal effective concentration: > 50000 nM
Compound 3: no number, only a limit; the forecaster's own chance of this, stated with the estimate: 3%; middle value at least 200-fold (2.30 log units) away from the limit.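

Placing (morpholin-4-yl)carbonyl in place of methoxy on this aromatic carbon gives an at least 380-fold higher number from compound 2 to compound 3 (2.58 log units; beyond the scatter), so in this assay this position, which the earlier compounds did not vary in a single-place comparison, does not accept every group. Compound 3 gives only a limit of the assay, not a number: the limit of > 50000 nM in this assay, at which 1 of the 3 values shown sits.

The compounds shown leave open whether the morpholine ring or the carbonyl linked to this carbon accounts for the step. Going by these compounds, what a dimethylamide, a carboxylic acid or an amine on this carbon would give also remains open.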